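This account rests on a few compounds, and the source may have more. Where it says the series, first, only, none or still open, it means among the compounds named here.

Compound 3 `CC(C)(C)c1nccn1CCC(C(N)=O)(c1ccccc1)c1ccccc1` gives 30.2 nM in an assay on ileum with muscarinic acetylcholine receptor M3 (Cavia porcellus) as the target (a lower number here means a stronger inhibitor, a higher number a weaker inhibitor), the second highest of the three numbers recorded; compound 1 `NC(=O)C(CCn1ccnc1)(c1ccccc1)c1ccccc1` gives 5.07 nM and compound 2 `CCCc1nccn1CCC(C(N)=O)(c1ccccc1)c1ccccc1` gives 177 nM. The step to compound 4 `Cc1ncn(CCC(C(N)=O)(c2ccccc2)c2ccccc2)c1C` is 4,5-dimethyl-1H-imidazol-1-yl in place of 2-(tert-butyl)-1H-imidazol-1-yl on a saturated chain carbon, three bonds along the chain from two aromatic carbons and a carbonyl carbon. Among the measured compounds shown here, the steps that bear on it are a 6.0-fold higher number from compound 1 to compound 3 (0.77 log units; beyond the scatter) and a 35-fold higher number from compound 1 to compound 2 (1.54 log units; beyond the scatter), which show that a group on the aromatic carbon of the imidazole raised the number, and a 5.9-fold lower number from compound 2 to compound 3 (0.77 log units; beyond the scatter). For the measured compounds named here, compound 4 carries no group on that carbon, so the number is expected to move back toward that of compound 1, though the two methyls have no measured counterpart. Compound 4 is therefore expected at 10 nM in this assay, with a range from 3 nM to 40 nM, a step of a 3.0-fold lower number from compound 3 to compound 4 (0.48 log units; beyond the scatter).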

Compound 4, antagonist equilibrium constant: 2.7 nM
Compound 4: the middle estimate sits 3.7-fold (0.57 log units) above what was measured; measured number below the stated range.
By their numbers in this assay, from the lowest: compounds 4 and 1 (each within the scatter of the next); then compound 3; then compound 2.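

In this assay, the 4,5-dimethyl-1H-imidazol-1-yl group does not carry the penalty seen with the 2-substituted groups, with an 11-fold lower number from compound 3 to compound 4 (1.05 log units; beyond the scatter) and a 66-fold lower number from compound 2 to compound 4 (1.82 log units; beyond the scatter). Against the unsubstituted 1H-imidazol-1-yl group, the result is a 1.9-fold lower number from compound 1 to compound 4 (0.27 log units; within the scatter), so added carbon on the imidazole does not by itself raise the number: the 2-propyl and 2-(tert-butyl) groups of compound 2 and compound 3 do, the two methyls of compound 4 do not. No measurement shown here accounts for this difference. Still open, going by these compounds, is how a single methyl or an ethyl group in place of the two methyls would read.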